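This account rests on a few compounds, and the source may have more. Where it says the series, first, only, none or still open, it means among the compounds named here.

The measured compounds:
compound 1 `Cc1ccccc1-n1nncc1CN1C(=O)C2(C(C#N)=C(N)Oc3c2c2nc4ccccc4nc2c2ccccc32)c2ccccc21`: > 50000 nM
compound 2 `N#CC1=C(N)Oc2c(c3nc4ccccc4nc3c3ccccc23)C12C(=O)N(Cc1cnnn1-c1ccc(Br)cc1)c1ccccc12`: 36600 nM
compound 3 `COc1ccccc1-n1nncc1CN1C(=O)C2(C(C#N)=C(N)Oc3c2c2nc4ccccc4nc2c2ccccc32)c2ccccc21`: > 50000 nM

In a functional assay on MCF7 cells (Homo sapiens) for antiproliferative activity, read by MTT assay, with a stated time of 48 h (on this read-out lower numbers stand for stronger inhibition and higher numbers for weaker inhibition), compound 1 gives > 50000 nM, which is a limit of the assay rather than a number. Compound 3 likewise gives only a limit, > 50000 nM. Compound 2 gives a number, 36600 nM. Compound 1 thus stands at the limit of > 50000 nM in this assay, at which 2 of the 3 values shown sit. Compound 4 `N#CC1=C(N)Oc2c(c3nc4ccccc4nc3c3ccccc23)C12C(=O)N(Cc1cnnn1-c1ccc(S(N)(=O)=O)cc1)c1ccccc12` differs from compound 1 in one place: 4-sulfamoylphenyl in place of 2-methylphenyl on an aromatic nitrogen. Going by the values given here, the steps that bear on it are the other aryl swaps on the same aromatic nitrogen: an at least 1.3-fold lower number from compound 1 to compound 2 (0.13 log units; that floor lies within the scatter) and an at least 1.3-fold higher number from compound 2 to compound 3 (0.13 log units; that floor lies within the scatter), both small, and a step that the two limits leave unreadable from compound 1 to compound 3. A step no larger than the scatter is expected in this assay, at most toward lower numbers, so compound 4 is expected at 40000 nM within 15000 nM to 80000 nM, a move of an at least 1.2-fold lower number from compound 1 to compound 4 (0.09 log units; that floor lies within the scatter).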

Compound 4, half-maximal inhibitory concentration: > 50000 nM
Compound 4: only a limit was reported; the forecaster's own chance of this, stated with the estimate: 50%; middle value at least 1.2-fold (0.09 log units) away from the limit.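

In this assay compound 4 gives only > 50000 nM, which is a limit and not a number. Sulfamoyl in place of bromo on the aromatic carbon gives an at least 1.3-fold higher number from compound 2 to compound 4 (0.13 log units; that floor lies within the scatter), and the steps to compound 4 from compound 1 and from compound 3 cannot be read. A 4-sulfamoylphenyl group, with its hydrogen-bond donor, therefore brings no readable gain at this position: the limit of > 50000 nM in this assay, at which 3 of the 4 values shown sit.

From the compounds shown here alone, whether an amine or a carboxylic acid on that phenyl ring would give a step beyond the scatter stays open. So does the effect of a longer alkyl chain in place of the aryl group on the aromatic nitrogen.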